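The source may hold more compounds than are shown below. What is called first, only, known or untested is meant among the compounds shown, and "the series" means these compounds.

Compound 2 `COc1cc(Cl)cc(-c2nn(-c3cccc(NC(=O)Nc4ccc(Cl)c(C(F)(F)F)c4)c3)cc2-c2ccncc2)c1` gives 68% in a functional assay on SNB-75 cells (Homo sapiens) for inhibition, read by sulforhodamine B assay, with a stated time of 48 h, tested at 1 uM; a lower number here means a stronger effect, a higher number a weaker effect of the compound at the concentration tested. Among the three compounds measured it stands highest, that is, weakest: compound 1 `O=C(Nc1cccc(-n2cc(-c3ccncc3)c(-c3cc(O)cc(Cl)c3)n2)c1)Nc1ccc(Cl)c(C(F)(F)F)c1` gives 54%, and compound 3 `COc1cc(Cl)cc(-c2nn(-c3cccc(NC(=O)Nc4cc(C(F)(F)F)cc(C(F)(F)F)c4)c3)cc2-c2ccncc2)c1` gives 48%. Going by the values given here, the one step measured between close neighbours is a number 14 percentage points higher from compound 1 to compound 2 (beyond the scatter), a change at a different place in the molecule. Compound 4 `COc1cc(Cl)cc(-c2nn(-c3cccc(NC(=O)c4cccc(C(F)(F)F)c4)c3)cc2-c2ccncc2)c1` differs from compound 2 in one place: 3-(trifluoromethyl)phenyl in place of (4-chloro-3-(trifluoromethyl)phenyl)amino on a carbonyl carbon. Among the compounds with values here, no measured step touches this part of the structure, so the earlier step offers no direct guide, and the expectation rests on the change alone. Compound 4 is expected to give 78%, with a range from 60% to 95%. The expected step is therefore a number 10 percentage points higher from compound 2 to compound 4 (within the scatter), a modest rise, though a result within the scatter would not surprise.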

Compound 4, a percentage reported as activity, at one concentration (the size of the read-out at that concentration, not a potency): 70%
Compound 4: middle estimate off by 8 percentage points, on the high side; the range from low to high includes it.
By their numbers in this assay, from the lowest: compounds 3 and 1 (each within the scatter of the next); then compounds 2 and 4 (each within the scatter of the next).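

Putting 3-(trifluoromethyl)phenyl in place of (4-chloro-3-(trifluoromethyl)phenyl)amino on a carbonyl carbon gives a number 2 percentage points higher from compound 2 to compound 4 (within the scatter) in this assay at this position. The entering group lacks the chlorine and the hydrogen-bond donor of the leaving group, yet the two compounds stay within the scatter of each other at this one concentration. No measurement shown gives a reason for this.

The separate contributions of the chlorine and the nitrogen remain unresolved. A piperidine or a longer chain on this carbonyl carbon remains an open case.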